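Compound 3 to compound 4: 3-fluorophenyl for 2-methoxyphenyl

The source may hold more compounds than are shown below. What is called first, only, known or untested is meant among the compounds shown, and "the series" means these compounds.

In a functional assay on MCF7 cells (Homo sapiens) for inhibition, read by MTT assay, with a stated time of 72 h (a lower number here means a stronger inhibitor, a higher number a weaker inhibitor), compound 1 `O=C(Nc1ccccc1)C1CCN(C/C=C/c2ccccc2)CC1` gives 60200 nM. Compound 2 `COc1ccc(NC(=O)C2CCN(C/C=C/c3ccccc3)CC2)cc1` reads > 100000 nM, which is a limit of the assay. Compound 3 `COc1ccccc1NC(=O)C1CCN(C/C=C/c2ccccc2)CC1` reads > 100000 nM, likewise only a limit and not a number.

Compound 4 `O=C(Nc1cccc(F)c1)C1CCN(C/C=C/c2ccccc2)CC1` carries 3-fluorophenyl in place of 2-methoxyphenyl on an amide-type nitrogen. The methoxy goes, which leaves compound 4 without that group, as in compound 1.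

For the measured compounds named here, two measured steps bear on this change: an at least 1.6-fold higher number from compound 1 to compound 2 (0.22 log units; that floor lies within the scatter) and an at least 1.6-fold higher number from compound 1 to compound 3 (0.22 log units; that floor lies within the scatter). Both are methoxy in place of hydrogen on an aromatic carbon. The third, a step that the two limits leave unreadable from compound 2 to compound 3, adds nothing. Going by the values given here, no measured compound carries fluorine, so the anchor is compound 1 at 60200 nM.

The expected change is an at least 1.4-fold lower number from compound 3 to compound 4 (0.15 log units; that floor lies within the scatter), towards a lower number in this assay and modest in size. Compound 4 is estimated at 70000 nM, with an expected range of 30000 nM to 140000 nM.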

Compound 4, half-maximal inhibitory concentration: 33000 nM
Beside the measured number, compound 4's estimate is 2.1-fold (0.33 log units) above it; measured number inside the range.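

In this assay the 3-fluorophenyl on an amide-type nitrogen gives a readable number where 2-methoxyphenyl and 4-methoxyphenyl gave only limits, with an at least 3.0-fold lower number from compound 3 to compound 4 (0.48 log units; beyond the scatter) and an at least 3.0-fold lower number from compound 2 to compound 4 (0.48 log units; beyond the scatter) as the steps beyond the scatter. Fluoro in place of hydrogen on an aromatic carbon gives a 1.8-fold lower number from compound 1 to compound 4 (0.26 log units; within the scatter) and so is not told apart from hydrogen in this series. The two steps from the methoxy compounds are floors and not sizes, because compound 2 and compound 3 are known only as limits of the assay: the limit of > 100000 nM in this assay, at which 2 of the 4 values shown sit.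

The step between compound 2 and compound 3 cannot be read, so the two methoxyphenyl groups cannot be ranked against each other. Open as well is how an amine or a carboxylic acid on the aromatic ring would compare with the fluoro of compound 4 in this assay on this shared core.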